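This account rests on a few compounds, and the source may have more. Where it says the series, first, only, none or still open, it means among the compounds named here.

This piece follows the path from compound 3 to compound 4 in a functional assay on SK-BR-3 cells (Homo sapiens) for antiproliferative activity, read by MTT assay, with a stated time of 72 h; a lower number here means a stronger inhibitor, a higher number a weaker inhibitor. Compound 3 has the structure `C/C=C1/[C@H](O[C@@H]2O[C@H](COC(C)=O)[C@@H](OC(C)=O)[C@H](OC(C)=O)[C@H]2OC(C)=O)OC=C(C(=O)OC)[C@H]1CC(=O)OC`. In this assay compound 3 gives > 15000 nM, which is a limit of the assay and not a number. The two other measured compounds also show only limits. Compound 1, with the structure `C#CCOC(=O)C[C@@H]1C(C(=O)OC)=CO[C@@H](O[C@@H]2O[C@H](CO)[C@@H](O)[C@H](O)[C@H]2O)/C1=C/C`, gives > 15000 nM in this assay, again a limit. Compound 2, with the structure `C/C=C1/[C@H](O[C@@H]2O[C@H](COC(C)=O)[C@@H](OC(C)=O)[C@H](OC(C)=O)[C@H]2OC(C)=O)OC=C(C(=O)O)[C@H]1CC(=O)OC`, gives > 20000 nM in this assay, also a limit. Compound 2 differs from compound 3 by methyl in place of hydrogen on an oxygen next to a carbonyl group, and the step that the two limits leave unreadable from compound 2 to compound 3 is unreadable, both of its values being limits. All that is known rests on the limit of > 15000 nM in this assay, at which 2 of the 3 values shown sit, and on (the limit of > 20000 nM in this assay, at which 1 of the 3 values shown sits).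

Compound 4 has the structure `C/C=C1/[C@H](O[C@@H]2O[C@H](COC(C)=O)[C@@H](OC(C)=O)[C@H](OC(C)=O)[C@H]2OC(C)=O)OC=C(C(=O)OC)[C@H]1CC(=O)OCCCC`. It differs from compound 3 by propyl in place of hydrogen on a saturated chain carbon bound to an oxygen next to a carbonyl group. Among the measured compounds shown here, no measured step resembles this change, and every value so far is a limit, so the step that the limit leaves unreadable from compound 3 to compound 4 is expected to leave compound 4 at a limit too, with no direction readable beyond the scatter. Compound 4 is therefore expected to give about 20000 nM in this assay, within 8000 nM to 60000 nM, most likely reported only as a limit.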

Compound 4, half-maximal inhibitory concentration: > 15000 nM
Compound 4 was reported as a limit (the forecaster's own chance of this, stated with the estimate: 80%); the middle value does not contradict the limit.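

Compound 3 and compound 4 both give only a limit in this assay, so the change from methoxycarbonyl to butoxycarbonyl cannot be read as a step in either direction. None of the four compounds shown has a value that is more than a limit, which leaves open how strongly any of them inhibits these cells.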